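Halogen swap on the anilino arm of a weak series

The source may hold more compounds than are shown below. What is called first, only, known or untested is meant among the compounds shown, and "the series" means these compounds.

Measured so far in a functional assay on SAOS-2 cells (Homo sapiens) for antiproliferative activity, read by MTT assay, with a stated time of 72 h; on this read-out lower numbers stand for stronger inhibition and higher numbers for weaker inhibition:
- compound 1 `O=C(C1=C(O)C(=O)N(CCCn2ccnc2)C1c1ccc(Br)cc1)c1ccccc1`: 31600 nM
- compound 2 `CCOC1=C(C(=O)c2ccccc2)C(c2ccc(Br)cc2)N(CCCn2ccnc2)C1=O`: 31700 nM
- compound 3 `O=C(C1=C(Nc2ccc(Br)cc2)C(=O)N(CCCn2ccnc2)C1c1ccc(Br)cc1)c1ccccc1`: 23800 nM

Compound 3 holds the lowest of the three numbers, but both of its neighbours sit inside the usual scatter: a 1.3-fold lower number from compound 1 to compound 3 (0.12 log units; within the scatter) and a 1.3-fold lower number from compound 2 to compound 3 (0.12 log units; within the scatter) are each too small to separate the compounds, so no ordering among the three can be claimed. Likewise a 1.0-fold higher number from compound 1 to compound 2 (0.00 log units; within the scatter) shows that exchanging hydroxy for ethoxy on the double-bonded ring carbon left the read-out unchanged. All three measured steps concern that one position on the shared core; the aryl groups themselves were never varied.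

Compound 4 `O=C(C1=C(Nc2ccc(Cl)cc2)C(=O)N(CCCn2ccnc2)C1c1ccc(Br)cc1)c1ccccc1` differs from compound 3 by chloro in place of bromo on an aromatic carbon. Going by the values given here, no measured step touches this halogen, so there is no direct precedent in this assay for the change. What the series does show is a flat response to every substitution tried so far, all within scatter. On that basis the step is expected to be small, a 1.1-fold higher number from compound 3 to compound 4 (0.02 log units; within the scatter), with no direction beyond the scatter.

For compound 4 the estimate in this assay is 25000 nM, with a range of 10000 nM to 60000 nM.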

Compound 4, half-maximal inhibitory concentration: 24800 nM
Compound 4: middle estimate off by 1.0-fold (0.00 log units), on the high side; measured number inside the range.
By their numbers in this assay, from the lowest: compounds 3, 4, 1 and 2 (each within the scatter of the next).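

In this assay the halogen on the anilino arm now has a measured step of its own (a 1.0-fold higher number from compound 3 to compound 4 (0.02 log units; within the scatter)), so chloro and bromo cannot be told apart at this place, para to a large group on the six-membered aromatic ring. Compound 4 also stays level with the two compounds that carry no anilino arm at the double-bonded ring carbon (a 1.3-fold lower number from compound 2 to compound 4 (0.11 log units; within the scatter); a 1.3-fold lower number from compound 1 to compound 4 (0.11 log units; within the scatter)), so the flat response across hydroxy, ethoxy and (4-bromophenyl)amino extends to (4-chlorophenyl)amino, and none of the four compounds goes against it. No supporting data are available to explain this flat response.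

From the compounds shown here alone, whether a fluoro, an amine or a carboxylic acid in place of the halogen on the anilino arm would move the number beyond the scatter remains open. Also open, going by these compounds, is whether any change elsewhere on the shared core, such as a longer chain on the ring nitrogen or a replacement for the other aryl groups, would separate compounds that are so far indistinguishable in this assay.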